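A few compounds are considered here, and "the series" means these few. Any claim that something is new, unique, unknown or untested is made for them only; others in the source may bear on it.

Measured compounds in an assay on isolated protein for displacement of a labelled ligand from 5-hydroxytryptamine receptor 6 (Homo sapiens), read by scintillation counting, with a stated time of 1 h; a higher number here means a weaker inhibitor, a lower number a stronger inhibitor:

compound 1 `O=S(=O)(c1ccccc1)n1ccc2c(O)cccc21` gives 108 nM
compound 2 `COc1ccc2c(ccn2S(=O)(=O)c2ccccc2)c1` gives 127 nM
compound 3 `O=S(=O)(c1ccccc1)n1cc(-c2ccncc2)c2ccccc21` gives 124 nM

The three measured compounds share a core carrying the same phenylsulfonyl group on the ring nitrogen and differ only in the substituent placed on the remaining ring positions. Among the measured compounds shown here, compound 1 has the lowest number of the three, but its gaps to compound 3 and to compound 2 both lie within the scatter, so the three values are best read as one cluster with no compound set apart.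

Compound 4 `O=S(=O)(c1ccccc1)n1ccc2c(-c3ccncc3)cccc21` differs from compound 1 in one place: pyridin-4-yl in place of hydroxy on an aromatic carbon. For the measured compounds named here, no measured pair in this set isolates this exact change. Compound 3 carries the same pyridin-4-yl group at a different position of the core and gives 124 nM, a number within the scatter of compound 1; this is the only indirect pointer available. On that basis the step from compound 1 to compound 4 is expected to be small, with no clear direction beyond the scatter, with a slight lean toward a weaker inhibitor given the removal of the hydroxy donor: the expected step is a 1.4-fold higher number from compound 1 to compound 4 (0.14 log units; within the scatter). For compound 4 in this assay an estimated value of 150 nM is expected, within a range from 50 nM to 500 nM.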

Compound 4, inhibition constant: 1510 nM
Compound 4: the middle estimate sits 10-fold (1.00 log units) below what was measured; the whole stated range lies below it.
By their numbers in this assay, from the lowest: compounds 1, 3 and 2 (each within the scatter of the next); then compound 4.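

In this assay, among the compounds shown here, pyridin-4-yl in place of hydroxy on this aromatic carbon gives a 14-fold higher number from compound 1 to compound 4 (1.15 log units; beyond the scatter), the first step that lies beyond the scatter. The earlier compounds stood within the scatter of one another and gave no sign that a change on the shared core could shift the number this far; this aromatic carbon is now shown to be sensitive to what it carries, at least for this replacement, which exchanges 1 heavy atom for 6 and removes the only hydrogen-bond donor of the group that leaves. No measurement of any property or of binding is available to account for the size of the step.

For the compounds shown here, whether the step follows the loss of the hydrogen-bond donor or the arrival of the six-membered aromatic ring stays open; the single change contains both. A primary amine or a methyl group on this aromatic carbon, or a phenyl ring in place of pyridin-4-yl, would help to separate the two.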